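A few compounds are considered here, and "the series" means these few. Any claim that something is new, unique, unknown or untested is made for them only; others in the source may bear on it.

Three compounds have been measured in a functional assay on MCF7 cells (Homo sapiens) for inhibition, read by MTT assay, with a stated time of 48 h; a lower number here means a stronger inhibitor, a higher number a weaker inhibitor:

Compound 1 `CCOC(=O)C1=C(N/N=C(\c2ccc([N+](=O)[O-])cc2)N2CCN(c3ccc(F)cc3)CC2)Nc2[nH]nc(C)c2C1c1ccc(N(C)C)cc1`: > 100000 nM (a limit of the assay)
Compound 2 `CCOC(=O)C1=C(N/N=C(/Cl)c2ccc([N+](=O)[O-])cc2)Nc2[nH]nc(C)c2C1c1ccc(N(C)C)cc1`: 52700 nM
Compound 3 `CCOC(=O)C1=C(N/N=C(/Br)c2ccccc2)Nc2[nH]nc(C)c2C1c1ccc(N(C)C)cc1`: 78400 nM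

In this assay, compound 2 gives 52700 nM. It can be compared by number only with compound 3, and the step between them is a 1.5-fold higher number from compound 2 to compound 3 (0.17 log units; within the scatter). Compound 1 reports only a limit, (the limit of > 100000 nM in this assay, at which 1 of the 3 values shown sits).

Compound 4 `CCOC(=O)C1=C(N/C=N/c2ccc([N+](=O)[O-])cc2)Nc2[nH]nc(C)c2C1c1ccc(N(C)C)cc1` has not yet been measured. The structural change leading to it is a group of 11 heavy atoms (7 carbon, 2 nitrogen, 2 oxygen; one six-membered aromatic ring of carbon only) in place of a group of 12 heavy atoms (7 carbon, 2 nitrogen, 2 oxygen, 1 chlorine; one six-membered aromatic ring of carbon only), on an amine nitrogen. Within the data shown here, this replacement sits on an amine nitrogen, the same kind of place as the one measured change, a 1.5-fold higher number from compound 2 to compound 3 (0.17 log units; within the scatter). Among the measured compounds shown here, that single step is the only guide, and it stayed within the scatter, so no shift beyond the scatter is expected here. The expected step is a 1.1-fold higher number from compound 2 to compound 4 (0.06 log units; within the scatter).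

For compound 4 the estimate is 60000 nM. The expected range for compound 4 runs from 25000 nM to 100000 nM.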

Compound 4, half-maximal inhibitory concentration: 58600 nM
Compound 4: middle estimate off by 1.0-fold (0.01 log units), on the high side; low and high end bracket the measured number.
By their numbers in this assay, from the lowest: compounds 2, 4 and 3 (each within the scatter of the next). At a limit, above all of these: compound 1.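

In this assay, a group with no halogen takes the place of the chlorine-bearing group of compound 2 on the amine nitrogen, and the number barely moves: a 1.1-fold higher number from compound 2 to compound 4 (0.05 log units; within the scatter). The comparison with the bromine-bearing group gives the same picture, a 1.3-fold lower number from compound 3 to compound 4 (0.13 log units; within the scatter), so compound 2, compound 3 and compound 4 lie within the scatter of one another even though their groups differ in halogen and in heavy-atom count. No measurement shown here bears on why these steps stay so small.

Going by these compounds, the steps to compound 1 cannot be read, since its entry is a limit and not a number: the limit of > 100000 nM in this assay, at which 1 of the 4 values shown sits. It remains open whether a different kind of group at this amine nitrogen, such as a short alkyl chain or one carrying a carboxylic acid, would shift the number beyond the scatter.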